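The source may hold more compounds than are shown below. What is called first, only, known or untested is meant among the compounds shown, and "the series" means these compounds.

Measured compounds:
- compound 1, `COc1cc(-c2cc(/C=C/C(=O)c3ccc(Cl)c(Cl)c3)[nH]n2)cc(OC)c1OC`: in a functional assay on OVCAR-4 cells (Homo sapiens) for cytotoxicity, read by sulforhodamine B assay, with a stated time of 48 h, tested at 0.1 uM (a higher number here means a weaker effect of the compound at the concentration tested, a lower number a stronger effect), compound 1 gives 106%
- compound 2, `COc1ccc(C(=O)/C=C/c2cc(-c3cc(OC)c(OC)c(OC)c3)n[nH]2)cc1`: in this assay compound 2 gives 94%

Compound 2 stands at the lowest of the two numbers in this assay; its nearest neighbour is compound 1, which lies a number 12 percentage points lower from compound 1 to compound 2 (beyond the scatter) away, a difference beyond the scatter, though a modest one. The unmeasured compound 3, `COc1cc(-c2cc(/C=C/C(=O)c3ccc(F)c(F)c3)[nH]n2)cc(OC)c1OC`, differs from compound 2 in one place: 3,4-difluorophenyl in place of 4-methoxyphenyl on a carbonyl carbon. Within the data shown here, only one measured step bears on this change. The replacement of 3,4-dichlorophenyl by 4-methoxyphenyl on the carbonyl carbon gave a number 12 percentage points lower from compound 1 to compound 2 (beyond the scatter). Compound 3 carries a halogenated ring on that carbonyl carbon again, so the step is expected to run the other way, back toward the value of compound 1, and the expected size is a number 8 percentage points higher from compound 2 to compound 3 (within the scatter), which is about at the edge of the scatter. Compound 3 is therefore estimated to give 102% in this assay, within a range from 86% to 116%.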

Compound 3, a percentage reported as activity, at one concentration (the size of the read-out at that concentration, not a potency): 111%
Beside the measured number, compound 3's estimate is 9 percentage points below it; the range from low to high includes it.
By their numbers in this assay, from the lowest: compound 2; then compounds 1 and 3 (each within the scatter of the next).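

In this assay, putting 3,4-difluorophenyl in place of 4-methoxyphenyl on the carbonyl carbon gave a number 17 percentage points higher from compound 2 to compound 3 (beyond the scatter), so a second halogenated ring now separates from 4-methoxyphenyl, and the gap seen earlier with 3,4-dichlorophenyl no longer rests on one halogenated group alone. The two halogenated rings themselves cannot be told apart in this read-out: 3,4-difluorophenyl in place of 3,4-dichlorophenyl gave a number 5 percentage points higher from compound 1 to compound 3 (within the scatter), which leaves compound 2 as the only one of the three set apart, with a step beyond the scatter to each of the others. Nothing available here explains why 4-methoxyphenyl stands apart at this position.

From the compounds shown here alone, it remains open whether the separation of compound 2 goes with the methoxy group itself or simply with the absence of halogen, a question that an unsubstituted phenyl or a 4-aminophenyl on the same carbonyl carbon would help to settle. Also open, going by these compounds, is whether this separation, seen at a single concentration, would hold over a wider span of concentrations.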